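Quinolinyl sulfonamide series: shifting the sulfonyl attachment

This account rests on a few compounds, and the source may have more. Where it says the series, first, only, none or still open, it means among the compounds named here.

Measured so far:
compound 1 `COc1ccccc1N1CCN(CCCCNS(=O)(=O)c2cnc3ccccc3c2)CC1` gives 79 nM in an assay on HEK293 cells for displacement of a labelled ligand from 5-hydroxytryptamine receptor 7 (Homo sapiens), read by scintillation counting, with a stated time of 1 h; a lower number here means a stronger inhibitor, a higher number a weaker inhibitor
compound 2 `COc1ccccc1N1CCN(CCCCNS(=O)(=O)c2ccc3ncccc3c2)CC1` gives 132 nM in this assay

For the measured compounds named here, compound 2 holds the higher of the two numbers, yet its only comparator sits within the scatter: the sole measured step, a 1.7-fold higher number from compound 1 to compound 2 (0.22 log units; within the scatter), changed the ring attachment on the sulfonyl sulfur and stayed within the usual spread. Compound 3 `COc1ccccc1N1CCN(CCCCNS(=O)(=O)c2cccc3cccnc23)CC1` repeats that kind of change: quinolin-8-yl in place of quinolin-6-yl on a sulfonyl sulfur. With one attachment shift already shown to be within the scatter, no step beyond the scatter is expected in this assay, so a 1.1-fold higher number from compound 2 to compound 3 (0.06 log units; within the scatter) is the estimate. Compound 3 is therefore expected near 150 nM, in the range 60 nM to 400 nM.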

Compound 3, inhibition constant: 55 nM
For compound 3 the middle estimate is 2.7-fold (0.44 log units) above the measured one; the measured number lies below the stated range.
By their numbers in this assay, from the lowest: compounds 3, 1 and 2 (each within the scatter of the next, the first and the last beyond it).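

In this assay, for the compounds shown here, the attachment point on the sulfonyl sulfur now makes a readable difference: quinolin-8-yl in place of quinolin-6-yl gives a 2.4-fold lower number from compound 2 to compound 3 (0.38 log units; beyond the scatter) and is the only step among the three compounds beyond the scatter, though a modest one. Quinolin-8-yl in place of quinolin-3-yl gives a 1.4-fold lower number from compound 1 to compound 3 (0.16 log units; within the scatter) and does not separate the two compounds. No evidence bears on the origin of this difference. Still open, on these data alone, is whether quinolin-8-yl keeps this standing against a plain phenyl on the sulfonyl sulfur, or with a longer chain on the sulfonamide nitrogen.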